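Removing the Fluoro Group from a Weakly Active Amide

This account rests on a few compounds, and the source may have more. Where it says the series, first, only, none or still open, it means among the compounds named here.

Three amides share one core and differ only in the aryl group on the carbonyl carbon. Compound 1, `O=C(Nc1ccc(Cl)c(-c2nnc3c(Cl)cccn23)c1)c1cccc(Cl)c1`, carries a 3-chlorophenyl there; in a functional assay on AN3-CA cells (Homo sapiens) for antiproliferative activity, read by MTT assay, with a stated time of 72 h (on this read-out lower numbers stand for stronger inhibition and higher numbers for weaker inhibition), compound 1 gives 68400 nM. Compound 2, `O=C(Nc1ccc(Cl)c(-c2nnc3c(Cl)cccn23)c1)c1c(F)cccc1Cl`, carries a 2-chloro-6-fluorophenyl. In this assay compound 2 reaches only a limit of the assay, > 100000 nM, so no number is known for it. The step of an at least 1.4-fold higher number from compound 1 to compound 2 (0.16 log units; that floor lies within the scatter) is thus a floor rather than a measured size, resting on (the limit of > 100000 nM in this assay, at which 1 of the 2 values shown sits). Compound 3, `O=C(Nc1ccc(Cl)c(-c2nnc3c(Cl)cccn23)c1)c1ccccc1Cl`, differs from compound 2 by hydrogen in place of fluoro on an aromatic carbon; read a bond further out, 2-chloro-6-fluorophenyl becomes 2-chlorophenyl. Within the data shown here, the one available step is a floor within the scatter, so it gives no clear direction. Compound 3 is therefore expected to remain weak in this assay, with an estimate of 90000 nM and a range from 35000 nM to 230000 nM. The step this estimate implies is expected to read an at least 1.1-fold lower number from compound 2 to compound 3 (0.04 log units; that floor lies within the scatter).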

Compound 3, half-maximal inhibitory concentration: > 100000 nM
Compound 3 gave a limit, no number (the forecaster's own chance of this, stated with the estimate: 45%); middle value at least 1.1-fold (0.04 log units) from the limit.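

Compound 3 also stops at a limit of the assay in this assay (> 100000 nM), so it gives no number. Taking away the fluoro group therefore does not bring this amide back into the measurable range, and the step between compound 2 and compound 3 cannot be read, because both sit at that limit: the limit of > 100000 nM in this assay, at which 2 of the 3 values shown sit. The change from 3-chlorophenyl to 2-chlorophenyl gives an at least 1.4-fold higher number from compound 1 to compound 3 (0.16 log units; that floor lies within the scatter) and so shows no clear direction either.

As far as these compounds go, how far compound 2 and compound 3 lie beyond the limit remains open. So does whether an amine or a carboxylic acid on this aryl group, or a longer chain in its place, would give a clearly lower number than compound 1.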